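The source may report more compounds than this note shows. Statements on the series, on what has been measured and on what is new or still open speak of the compounds shown alone.

Compound 1 `Nc1nc(-c2ccco2)nc2sc(CN3CC=CCC3)cc12` and compound 2 `Nc1nc(-c2ccco2)nc2sc(CN3CC=CC3)cc12` share a core and differ in one group: a group of 5 heavy atoms (4 carbon, 1 nitrogen; one five-membered non-aromatic ring with 1 hetero atom) in place of a group of 6 heavy atoms (5 carbon, 1 nitrogen; one six-membered non-aromatic ring with 1 hetero atom), on a saturated chain carbon bound to an aromatic carbon. In an assay on CHO-K1 cells for antagonist activity at adenosine receptor A1 (Homo sapiens), read by a beta-galactosidase reporter, with stated times of 15 min and 6 h (a higher number here means a weaker inhibitor, a lower number a stronger inhibitor), compound 1 gives 150 nM, and compound 2 gives 290 nM, a step of a 1.9-fold higher number from compound 1 to compound 2 (0.29 log units; within the scatter). Compound 3 `N#Cc1ccc(-c2nc(N)c3cc(CN4CC=CCC4)sc3n2)cc1` carries a different core, the difference from compound 1 being (4-cyanophenyl in place of furan-2-yl on an aromatic carbon), and in this assay compound 3 gives 1630 nM, a step of an 11-fold higher number from compound 1 to compound 3 (1.04 log units; beyond the scatter). Compound 4 `N#Cc1ccc(-c2nc(N)c3cc(CN4CC=CC4)sc3n2)cc1` has not been measured. It differs from compound 3 by the same change that turns compound 1 into compound 2, at the same place: a group of 5 heavy atoms (4 carbon, 1 nitrogen; one five-membered non-aromatic ring with 1 hetero atom) in place of a group of 6 heavy atoms (5 carbon, 1 nitrogen; one six-membered non-aromatic ring with 1 hetero atom), on a saturated chain carbon bound to an aromatic carbon. Because that change measured once gave a 1.9-fold higher number from compound 1 to compound 2 (0.29 log units; within the scatter), a step of about the same size is expected here: a 1.9-fold higher number from compound 3 to compound 4 (0.28 log units; within the scatter). On that basis compound 4 is estimated at 3100 nM in this assay.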

Compound 4, inhibition constant: 2350 nM
For compound 4 the middle estimate is 1.3-fold (0.12 log units) above the measured one; measured number inside the range.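

In this assay, putting the five-membered ring in place of the six-membered ring gives a 1.4-fold higher number from compound 3 to compound 4 (0.16 log units; within the scatter), and this agrees with the same change on the core of compound 1: the same change on two cores in this assay, a 1.9-fold higher number (0.29 log units; within the scatter) from compound 1 to compound 2 and a 1.4-fold higher number (0.16 log units; within the scatter) from compound 3 to compound 4, 1.3-fold (0.13 log units) apart, within the scatter of two such steps. Putting 4-cyanophenyl in place of furan-2-yl gives an 8.1-fold higher number from compound 2 to compound 4 (0.91 log units; beyond the scatter), and this also agrees with the earlier step: the same change on two cores in this assay, an 11-fold higher number (1.04 log units; beyond the scatter) from compound 1 to compound 3 and an 8.1-fold higher number (0.91 log units; beyond the scatter) from compound 2 to compound 4, 1.3-fold (0.13 log units) apart, within the scatter of two such steps. Across these four compounds, each change therefore carries over from one core to the other, but this rests on just two steps per change in one assay and does not show that it would hold for other groups or cores.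

From the compounds shown here alone, it remains open whether the same holds for a piperidine or morpholine ring on the saturated chain carbon. Going by these compounds, it is also open whether it holds for an unsubstituted phenyl in place of furan-2-yl.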